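Removing the aryl group from compound 1

This account rests on a few compounds, and the source may have more. Where it says the series, first, only, none or still open, it means among the compounds named here.

Among the compounds with values here, compound 1 `O=C1O[C@H]([C@@H](O)Cn2cc(-c3cc(F)cc(F)c3)nn2)C(OCc2ccccc2)=C1OCc1ccccc1` is the only member with a number in a functional assay on HepG2 cells (Homo sapiens) for antiproliferative activity, read by MTT assay, with a stated time of 72 h (a lower number here means a stronger inhibitor, a higher number a weaker inhibitor), where compound 1 gives 11600 nM. Compound 2 `CCCCCc1ccc(-c2cn(C/C=C3\OC(=O)C(OCc4ccccc4)=C3OCc3ccccc3)nn2)cc1` reaches only the limit of this assay, > 100000 nM. Compound 3 `COc1ccccc1-c1cn(C/C=C2\OC(=O)C(OCc3ccccc3)=C2OCc2ccccc2)nn1` likewise stops at a limit, > 100000 nM. The step that the two limits leave unreadable from compound 2 to compound 3 therefore cannot be sized, because of the limit of > 100000 nM in this assay, at which 2 of the 3 values shown sit. Compound 4 `O=C1O[C@H]([C@@H](O)Cn2ccnn2)C(OCc2ccccc2)=C1OCc1ccccc1` differs from compound 1 by hydrogen in place of 3,5-difluorophenyl on an aromatic carbon. Within the data shown here, no measured step covers this change, and the two compounds at the limit differ from compound 1 elsewhere, so they give no direction. The expectation is a modest weakening in this assay, with the step of a 3.0-fold higher number from compound 1 to compound 4 (0.48 log units; beyond the scatter) as the estimate. Compound 4 is thus estimated at 35000 nM, in the range 8000 nM to 150000 nM.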

Compound 4, half-maximal inhibitory concentration: > 100000 nM
Compound 4: only a limit was reported; the forecaster's own chance of this, stated with the estimate: 35%; at least 2.8-fold (0.45 log units) between middle value and limit.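

In this assay, putting hydrogen in place of 3,5-difluorophenyl gives an at least 8.6-fold higher number from compound 1 to compound 4 (0.93 log units; beyond the scatter), the first step measured at this aromatic carbon on the core of compound 1. Within the data shown here, on this core, a number is so far seen only with the aryl group present. Compound 4 stands at a limit, so the step gives only a lower bound: the limit of > 100000 nM in this assay, at which 3 of the 4 values shown sit.

Going by these compounds, whether the fluorines or the phenyl ring itself carry this step remains open. So does the outcome with plain phenyl, a methyl group or an aminomethyl group on this carbon.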